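A few compounds are considered here, and "the series" means these few. Any claim that something is new, unique, unknown or untested is made for them only; others in the source may bear on it.

Compound 1, `CC(C)n1ncc2c(C(=O)Nc3ncccn3)cc(-c3cccs3)nc21`: 75000 nM
Compound 2, `CC(C)n1ncc2c(C(=O)Nc3ccccc3F)cc(-c3cccnc3)nc21`: 50000 nM
Compound 3, `CC(C)n1ncc2c(C(=O)Nc3cncnc3)cc(-c3cccs3)nc21`: 20000 nM

In an ADME assay on LLC-MK2 cells (Macaca mulatta) for cytotoxicity, read by spectrophotometry and crystal violet staining, with a stated time of 4 days (on this read-out higher numbers stand for lower toxicity in this test and lower numbers for higher toxicity in this test), compound 3 gives the lowest number of the three, so it is the most toxic in this test; compound 2 sits above it and compound 1 higher still, both beyond the scatter. Compound 4, `CC(C)n1ncc2c(C(=O)Nc3cccnc3)cc(-c3cccs3)nc21`, differs from compound 3 in one place: pyridin-3-yl in place of pyrimidin-5-yl on an amide-type nitrogen. Going by the values given here, only one measured step touches this position, a 3.8-fold lower number from compound 1 to compound 3 (0.57 log units; beyond the scatter), and it exchanged one pyrimidinyl for another; here a pyridin-3-yl enters instead, so that step is weak guidance. With nothing stronger to go on, no shift beyond the scatter is expected in this assay. Compound 4 is therefore expected to give about 25000 nM, within 10000 nM to 60000 nM, an expected step of a 1.3-fold higher number from compound 3 to compound 4 (0.10 log units; within the scatter).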

Compound 4, half-maximal cytotoxic concentration: > 200000 nM
Compound 4: only a limit was reported; the forecaster's own chance of this, stated with the estimate: 5%; middle value at least 8.0-fold (0.90 log units) away from the limit.
By their numbers in this assay, from the lowest: compound 3; then compounds 2 and 1 (each within the scatter of the next). At a limit, above all of these: compound 4.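

The change to pyridin-3-yl on the amide-type nitrogen gives an at least 10-fold higher number from compound 3 to compound 4 (1.00 log units; beyond the scatter), and the change from pyrimidin-2-yl gives an at least 2.6-fold higher number from compound 1 to compound 4 (0.42 log units; beyond the scatter). So in this assay this position can move the number further than the step between the two pyrimidinyl groups showed. Compound 4 stands at a limit of this assay, not at a number: the limit of > 200000 nM in this assay, at which 1 of the 4 values shown sits.

As far as these compounds go, how far the true value of compound 4 lies past that limit stays open, and with it the full size of both steps. Also open, from the compounds shown here alone, is how a pyridin-4-yl or a plain phenyl ring would behave on the same nitrogen.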